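A few compounds are considered here, and "the series" means these few. Any claim that something is new, unique, unknown or untested is made for them only; others in the source may bear on it.

Measured compounds:
compound 1, `Cn1c(=O)c(S(=O)(=O)Cc2ccc(F)cc2F)cc2cnc(Nc3ccc4[nH]ccc4c3)nc21`, 1000 nM
compound 2, `Cn1c(=O)c(S(=O)(=O)c2ccc(F)cc2F)cc2cnc(Nc3ccc4c(c3)CC(=O)N4)nc21`, 15000 nM
compound 3, `Cc1cc2cc(Nc3ncc4cc(S(=O)(=O)c5ccc(F)cc5F)c(=O)n(C)c4n3)ccc2[nH]1`, 750 nM

Of the compounds shown here, three sharing one core have been measured in a functional assay on K562 cells (Homo sapiens) for inhibition, read by trypan blue exclusion, with a stated time of 72 h; a higher number here means a weaker inhibitor, a lower number a stronger inhibitor. Compound 1 gives 1000 nM, the second highest of the three numbers; compound 3 stands nearest with a number that is lower but within the scatter, while compound 2 stands furthest with a number higher than compound 1 by a margin beyond the scatter. Going by the values given here, the only single-place step among the measured compounds is a 20-fold lower number from compound 2 to compound 3 (1.30 log units; beyond the scatter), a large change made on the nitrogen attached to the aromatic ring of the core.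

Compound 4, `Cn1c(=O)c(S(=O)(=O)c2ccc(F)cc2[N+](=O)[O-])cc2cnc(Nc3ccc4[nH]ccc4c3)nc21`, is now to be measured in this assay. It differs from compound 1 at the sulfonyl sulfur: 4-fluoro-2-nitrophenyl in place of 2,4-difluorobenzyl on a sulfonyl sulfur. Among the compounds with values here, no measured step changes the group on the sulfonyl sulfur alone, so the step from compound 2 to compound 3 does not bear on it directly. Compounds 1 and 3 differ in two places, one of them on the sulfonyl sulfur, and their numbers lie within the scatter of each other, which gives no sign of a large effect from that position. The step of a 1.2-fold higher number from compound 1 to compound 4 (0.08 log units; within the scatter) is therefore expected to stay within the scatter. Compound 4 is estimated at 1200 nM, with a range from 400 nM to 4000 nM.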

Compound 4, half-maximal inhibitory concentration: 900 nM
Compound 4: middle estimate off by 1.3-fold (0.12 log units), on the high side; the measured number falls inside the stated range.
By their numbers in this assay, from the lowest: compounds 3, 4 and 1 (each within the scatter of the next); then compound 2.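

In this assay, the step that changes the group on the sulfonyl sulfur and nothing else, a 1.1-fold lower number from compound 1 to compound 4 (0.05 log units; within the scatter), stays within the scatter, so 4-fluoro-2-nitrophenyl and 2,4-difluorobenzyl cannot be told apart at this position. The earlier compounds shown here offered only an indirect hint about this place, since compound 1 and compound 3 differ in two places; this pair isolates it. The exchange is not a small one on paper: 10 heavy atoms replace 9, 2 hydrogen-bond acceptors replace 0, and the two fluorines of the leaving group give way to one fluorine and a nitro group, yet the number holds within the scatter, and nothing among the data bears on why this should be so.

As far as these compounds go, this single pair covers one group on the aromatic amine nitrogen and two groups on the sulfonyl sulfur, so it remains open whether the same result would hold with the group carried by compound 2 or compound 3 at that nitrogen. It also leaves open how this assay would respond to quite different groups on the sulfonyl sulfur, such as a carboxylic acid, an amine or a longer alkyl chain.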